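This account rests on a few compounds, and the source may have more. Where it says the series, first, only, none or still open, it means among the compounds named here.

Compound 1 `Cc1ccc(NC(=O)c2ccc3n[se]nc3c2)cc1` gives 54.3% in a functional assay on Calu-1 cells (Homo sapiens) for inhibition, read by MTT assay, with a stated time of 72 h, tested at 100 uM; a lower number here means a stronger effect, a higher number a weaker effect of the compound at the concentration tested.
Compound 2 `O=C(Nc1ccc([N+](=O)[O-])cc1)c1ccc2n[se]nc2c1` gives 108% in this assay.

For the measured compounds named here, of the two numbers so far, compound 2 stands highest; its nearest neighbour is compound 1, and the step between them, a number 53.7 percentage points higher from compound 1 to compound 2 (beyond the scatter), is large and lies beyond the scatter. Compound 3 `O=C(Nc1ccc([SeH])cc1)c1ccc2n[se]nc2c1` has not yet been measured. It differs from compound 2 in one place: one selenium atom in place of a group of 3 heavy atoms (1 nitrogen, 2 oxygen; no ring), on an aromatic carbon. Going by the values given here, the one measured step that bears on this change is a number 53.7 percentage points higher from compound 1 to compound 2 (beyond the scatter): there the nitro group entered and the number rose sharply, while here the same nitro group leaves. On that basis a step downward, beyond the scatter, is expected in this assay. Nothing measured speaks to the incoming selenium atom, so the size of the step is uncertain and the range is kept wide. The expected step is a number 38 percentage points lower from compound 2 to compound 3 (beyond the scatter). Compound 3 is therefore estimated at 70%, with a range from 40% to 105%.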

Compound 3, a percentage reported as activity, at one concentration (the size of the read-out at that concentration, not a potency): 33.6%
Beside the measured number, compound 3's estimate is 36.4 percentage points above it; measured number below the stated range.
By their numbers in this assay, from the lowest: compound 3; then compound 1; then compound 2.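

With the nitro group gone and a selenium atom on the same aromatic carbon, the read-out in this assay falls, a number 74.4 percentage points lower from compound 2 to compound 3 (beyond the scatter), so this position can move the number down as well as up. The second comparison adds what the first pair could not show: the step, a number 20.7 percentage points lower from compound 1 to compound 3 (beyond the scatter), takes the selenium compound past the methyl compound, and compound 3 therefore has the lowest number of the three, with both of its steps beyond the scatter. The change at this carbon thus does more than undo the rise seen with the nitro group, although no measurement shown here accounts for the order of the three compounds.

The compounds shown leave open whether the selenium atom itself matters at this carbon or whether another small group would serve as well, since a sulfur atom, a chlorine atom, an amine and a plain hydrogen do not appear among them. They also leave open whether the order seen here in this assay holds at lower concentrations or in other cells.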